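The source may report more compounds than this note shows. Statements on the series, on what has been measured and on what is new or still open speak of the compounds shown alone.

Compound 1 `CCn1c(C(=O)NCCN(C)C)ccc1C(CC)(CC)c1ccc(OCC(=O)C(C)(C)C)c(C)c1` is one of three compounds that have been tested in an assay on HL-60 cells for agonist activity at vitamin D3 receptor (Homo sapiens), read by microscopy, with a stated time of 96 h; a higher number here means that more compound is needed for the effect, a lower number that less compound is needed. In this assay compound 1 gives 77 nM, the lowest of the three numbers. Compound 3 `CCn1c(C(=O)N(CCC#N)CCC#N)ccc1C(CC)(CC)c1ccc(OCC(O)C(C)(C)C)c(C)c1` comes closest: in this assay compound 3 gives 97 nM, which lies within the scatter of compound 1. Compound 2 `CCOC(=O)CN(C)C(=O)c1ccc(C(CC)(CC)c2ccc(OCC(O)C(C)(C)C)c(C)c2)n1CC` is furthest away; in this assay compound 2 gives 210 nM, beyond the scatter from compound 1. Going by the values given here, compounds 2 and 3 differ only in the group attached to a carbonyl carbon, and the step of a 2.2-fold lower number from compound 2 to compound 3 (0.34 log units; beyond the scatter) is the only single-point change measured so far.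

Compound 4 `CCn1c(C(=O)N(C)CC(=O)O)ccc1C(CC)(CC)c1ccc(OCC(=O)C(C)(C)C)c(C)c1` has not yet been measured. It differs from compound 1 in one place: (carboxymethyl)(methyl)amino in place of (2-(dimethylamino)ethyl)amino on a carbonyl carbon. Among the compounds with values here, this change also sits on a carbonyl carbon, so the step from compound 2 to compound 3 is the one comparison that bears on it, and that step was modest. The other compound with a different group on that carbonyl carbon is compound 2, and in this assay compound 2 gives 210 nM, the highest number of the three. A modest step in this assay is therefore expected, if any, toward a higher number: a 1.9-fold higher number from compound 1 to compound 4 (0.29 log units; within the scatter). Compound 4 is estimated at 150 nM, with a range from 60 nM to 400 nM.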

Compound 4, half-maximal effective concentration: 1390 nM
Compound 4: the middle estimate sits 9.3-fold (0.97 log units) below what was measured; measured number outside the range, above it.
By their numbers in this assay, from the lowest: compounds 1 and 3 (each within the scatter of the next); then compound 2; then compound 4.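

In this assay, the group on this carbonyl carbon proved able to shift the number strongly: (carboxymethyl)(methyl)amino in place of (2-(dimethylamino)ethyl)amino gives an 18-fold higher number from compound 1 to compound 4 (1.26 log units; beyond the scatter). Going by these compounds alone, the only earlier step at this carbonyl carbon, a 2.2-fold lower number from compound 2 to compound 3 (0.34 log units; beyond the scatter), was far smaller, so that modest step does not set the scale of what a change here can do. The computed counts of heavy atoms, hydrogen-bond donors and acceptors match for the two groups and neither holds a ring, so those counts do not account for the step, and no measurement in hand explains it.

This single step changes the group in more than one way, as a methyl replaces the amide hydrogen and a carboxylic acid stands where the dimethylamino end stood, so the shift cannot be assigned to either feature alone. A (carboxymethyl)amino group, which keeps the amide hydrogen, or the ethyl ester of the carboxymethyl group on the core of compound 1, would help separate these two features, and a longer chain carrying the carboxylic acid would show whether the distance of the acid from the carbonyl matters.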